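Compound 3 Without Its Chloro Group

The source may report more compounds than this note shows. Statements on the series, on what has been measured and on what is new or still open speak of the compounds shown alone.

In a functional assay on PC-3 cells (Homo sapiens) for inhibition, read by MTT assay, with a stated time of 48 h (on this read-out lower numbers stand for stronger inhibition and higher numbers for weaker inhibition), compound 1 `O=C(/C=C/c1ccccc1Br)c1ccc[nH]1` gives 44000 nM and compound 2 `O=C(/C=C/c1cc([N+](=O)[O-])ccc1Cl)c1ccc[nH]1` gives 55000 nM while compound 3 `O=C(/C=C/c1ccccc1Cl)c1ccco1` gives 14000 nM as the lowest of the three numbers, with both gaps beyond the usual scatter. Compound 4 `O=C(/C=C/c1ccccc1)c1ccco1` has not yet been measured. It differs from compound 3 by hydrogen in place of chloro on an aromatic carbon with hydrogen in place of chloro on an aromatic carbon. Among the compounds with values here, no measured pair shows this change on its own, so any expectation remains loose. A small move toward weaker inhibition is expected in this assay and the estimated size is a 2.0-fold higher number from compound 3 to compound 4 (0.30 log units; within the scatter) at about the edge of the scatter. The estimate for compound 4 is 28000 nM with an expected range from 10000 nM to 75000 nM on this read-out.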

Compound 4, half-maximal inhibitory concentration: > 100000 nM
Compound 4 was reported as a limit; the forecaster's own chance of this, stated with the estimate: 10%; middle value at least 3.5-fold (0.55 log units) away from the limit.
By their numbers in this assay, from the lowest: compound 3; then compounds 1 and 2 (each within the scatter of the next). At a limit, above all of these: compound 4.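

In this assay, compound 4 gives > 100000 nM, which is a limit of the assay and not a number. Within the data shown here, this pair is the first to show the change on its own: hydrogen in place of chloro on an aromatic carbon, ortho to a group of 9 heavy atoms, gives an at least 7.1-fold higher number from compound 3 to compound 4 (0.85 log units; beyond the scatter), so here the chloro goes with the stronger inhibition. Only a lower bound on the size of this step is known: the limit of > 100000 nM in this assay, at which 1 of the 4 values shown sits.

The compounds shown leave open whether a methoxy group or an amine at this position would keep the inhibition seen with chloro. They also give no reason for the step.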